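Notes on a further fluoro on compound 3

This account rests on a few compounds, and the source may have more. Where it says the series, first, only, none or still open, it means among the compounds named here.

Compound 1 `Nc1ncnc2[nH]cc(-c3ccc(NC(=O)c4cn(CC5CCOCC5)cc(-c5ccc(F)cc5)c4=O)cc3)c12` gives 77.9 nM
Compound 2 `Cn1cc(-c2ccc(NC(=O)c3cn(CC4CCOCC4)cc(-c4ccc(F)cc4F)c3=O)cc2)c2c(N)ncnc21` gives 501 nM
Compound 3 `Cn1cc(-c2ccc(NC(=O)c3cn(CC4CCOCC4)cc(-c4ccc(F)cc4)c3=O)c(F)c2)c2c(N)ncnc21` gives 210 nM

All three compounds were tested in a functional assay on MKN-45 cells (Homo sapiens) for antiproliferative activity, with a stated time of 72 h (on this read-out lower numbers stand for stronger inhibition and higher numbers for weaker inhibition), and give the values above. Compound 3 (210 nM) holds the middle place among the three numbers, with compound 1 lower and compound 2 higher. Both gaps lie beyond the scatter. No two of the measured compounds differ in only one place, so the series offers no measured single change to use as a guide.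

The next compound is compound 4 `Cn1cc(-c2cc(F)c(NC(=O)c3cn(CC4CCOCC4)cc(-c4ccc(F)cc4)c3=O)cc2F)c2c(N)ncnc21`, which departs from compound 3 by one change (fluoro in place of hydrogen on an aromatic carbon). This is fluoro in place of hydrogen on an aromatic carbon, ortho to a large group, meta to a large group and para to a fluoro group. Among the measured compounds shown here, with no measured precedent for this change, the expectation starts from compound 3 at 210 nM and assumes only a small upward move in the number, none beyond the scatter. The estimated change in this assay is a 1.2-fold higher number from compound 3 to compound 4 (0.08 log units; within the scatter) and would stay within the scatter. For compound 4 the expected value is 250 nM with an estimated range from 90 nM to 700 nM in this read-out.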

Compound 4, half-maximal inhibitory concentration: 53.7 nM
Estimate against measurement, compound 4: 4.7-fold (0.67 log units) above, and the stated range ends above it.
By their numbers in this assay, from the lowest: compounds 4 and 1 (each within the scatter of the next); then compound 3; then compound 2.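

Fluoro in place of hydrogen on an aromatic carbon gives a 3.9-fold lower number from compound 3 to compound 4 (0.59 log units; beyond the scatter) in this assay and is the first single change that can be read in this series. As far as these compounds go, the position, ortho to a large group, meta to a large group and para to a fluoro group, is therefore one where a single added fluoro moves the number downward beyond the scatter, so the six-membered aromatic ring carrying it is open to substitution here without loss in this read-out. No measurement at hand speaks to what lies behind the step.

Still open, from the compounds shown here alone, is whether the step is specific to fluoro or would also follow from another group at the same place, such as chloro, methyl, methoxy or an amine, and these would separate an effect of fluoro from one of any substituent there. Also open, going by these compounds, is whether the step depends on the fluoro group para to this position, a question that only the same new fluoro on a ring lacking that partner could settle, and whether the step carries over to the other compounds.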